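Chloro for fluoro on the amide benzyl of compound 3

This account rests on a few compounds, and the source may have more. Where it says the series, first, only, none or still open, it means among the compounds named here.

Compound 1, `CC(C)c1c(C(=O)NCc2ccccc2)nn(-c2ccc(F)cc2)c1OC[C@@H](O)C[C@@H](O)CC(=O)O`, gives 3.8 nM in an assay on microsomes from liver for inhibition of 3-hydroxy-3-methylglutaryl-coenzyme A reductase (Rattus norvegicus); a lower number here means a stronger inhibitor, a higher number a weaker inhibitor.
Compound 2, `CC(C)c1c(C(=O)N2CCCC2c2ccccc2)nn(-c2ccc(F)cc2)c1OC[C@@H](O)C[C@@H](O)CC(=O)O`, gives 14 nM.
Compound 3, `CC(C)c1c(C(=O)N(C)Cc2cccc(F)c2)nn(-c2ccc(F)cc2)c1OC[C@@H](O)C[C@@H](O)CC(=O)O`, gives 14 nM.

Compound 3 stands level with compound 2 at the digits printed, and these two carry the highest numbers of the three. Going by the values given here, compound 1 is the furthest from compound 3; the only steps beyond the scatter are a 3.7-fold higher number from compound 1 to compound 3 (0.57 log units; beyond the scatter) and a 3.7-fold higher number from compound 1 to compound 2 (0.57 log units; beyond the scatter), both changes on the amide nitrogen, while no change at the digits printed from compound 2 to compound 3 (within the scatter).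

Compound 4, `CC(C)c1c(C(=O)N(C)Cc2cccc(Cl)c2)nn(-c2ccc(F)cc2)c1OC[C@@H](O)C[C@@H](O)CC(=O)O`, differs from compound 3 by one change: chloro in place of fluoro on an aromatic carbon. Among the compounds with values here, none of the measured steps touches this position; all three involve the substituent on the carbonyl carbon, not a halogen on the benzyl ring. Within the data shown here, the data therefore give no measured precedent for this swap, and in this assay the default expectation is a step of no more than the scatter in either direction.

Compound 4 is accordingly estimated at about 14 nM in this assay, with a range from 6 nM to 35 nM, meaning an expected step of no change at the digits printed from compound 3 to compound 4 (within the scatter).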

Compound 4, half-maximal inhibitory concentration: 8.3 nM
Compound 4: middle estimate off by 1.7-fold (0.23 log units), on the high side, within the range that was stated.
By their numbers in this assay, from the lowest: compound 1; then compounds 4, 2 and 3 (each within the scatter of the next).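

In this assay, going by these compounds alone, this is the first measured change of halogen on the benzyl ring, and replacing fluoro with chloro gives a 1.7-fold lower number from compound 3 to compound 4 (0.23 log units; within the scatter) at this place on the ring, so the two halogens cannot be told apart here. The (3-chlorobenzyl)(methyl)amino amide also cannot be separated from the 2-phenylpyrrolidin-1-yl amide, with a 1.7-fold lower number from compound 2 to compound 4 (0.23 log units; within the scatter) between them, while the benzylamino amide remains apart from it, with a 2.2-fold higher number from compound 1 to compound 4 (0.34 log units; beyond the scatter) as the step, so the gap seen with the fluoro compound persists beyond the scatter with chloro. No measurement shown here offers an explanation for any of these steps.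

The compounds shown leave open how larger or different groups at this place on the ring, such as trifluoromethyl, methoxy or nitrile, would read in this assay and whether the insensitivity extends beyond the two halogens. The step from compound 1 also joins the amide methyl and the ring halogen in a single change, so a (benzyl)(methyl)amino amide with no halogen, or a 3-chlorobenzylamino amide that keeps the amide hydrogen, would be needed to separate their contributions.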